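Working notes: a fluoro step and its expected size

The source may hold more compounds than are shown below. What is called first, only, known or untested is meant among the compounds shown, and "the series" means these compounds.

Measured so far in a functional assay on HL-60 cells (Homo sapiens) for inhibition, read by MTT assay, with a stated time of 72 h; a higher number here means a weaker inhibitor, a lower number a stronger inhibitor:
compound 1, `Cc1ccc(C)c(N2CCN(C(=O)c3oc(C)nc3-c3ccccc3)CC2)c1`, gives 31.3 nM.
compound 2, `Cc1ccc(C)c(N2CCN(C(=O)c3oc(C)nc3-c3ccccc3F)CC2)c1`, gives 319 nM.
compound 3, `Cc1nc(-c2ccccc2)c(C(=O)N2CCN(c3cc(Cl)cc(Cl)c3)CC2)o1`, gives 41.8 nM.

Compound 3 differs from compound 1 in 3,5-dichlorophenyl in place of 2,5-dimethylphenyl on an amine nitrogen in a ring, and in this assay that step reads a 1.3-fold higher number from compound 1 to compound 3 (0.13 log units; within the scatter). Compound 2 carries fluoro in place of hydrogen on an aromatic carbon, and in this assay the step is a 10-fold higher number from compound 1 to compound 2 (1.01 log units; beyond the scatter).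

Compound 4, `Cc1nc(-c2cccc(F)c2)c(C(=O)N2CCN(c3cc(Cl)cc(Cl)c3)CC2)o1`, is not yet measured. Relative to compound 3 it carries fluoro in place of hydrogen on an aromatic carbon. Among the compounds with values here, this is the same kind of change as the one from compound 1 to compound 2, but the place is not the same word for word: in compound 2 the fluoro sits ortho to a large group, in compound 4 it sits meta to a large group. Within the data shown here, the step from compound 3 to compound 4 is expected to weaken inhibition, estimated at a 3.6-fold higher number from compound 3 to compound 4 (0.55 log units; beyond the scatter), resting on the single precedent a 10-fold higher number from compound 1 to compound 2 (1.01 log units; beyond the scatter) while allowing a smaller step. The place of the fluoro in compound 4 is not the same as in compound 2, and that is where the room for a smaller step comes from. Compound 4 is therefore expected to give about 150 nM, with a range from 40 nM to 600 nM.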

Compound 4, half-maximal inhibitory concentration: 41.7 nM
Beside the measured number, compound 4's estimate is 3.6-fold (0.56 log units) above it, within the range that was stated.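

In this assay, fluoro in place of hydrogen reads a 1.0-fold lower number from compound 3 to compound 4 (0.00 log units; within the scatter), so the change does not carry a fixed step from one core to the other, and the two cases clearly part: the same change on two cores in this assay, a 10-fold higher number (1.01 log units; beyond the scatter) from compound 1 to compound 2 and a 1.0-fold lower number (0.00 log units; within the scatter) from compound 3 to compound 4, 10-fold (1.01 log units) apart, beyond the scatter of two such steps

This does not show what sets the two steps apart, since they differ both in the place of the fluoro, which in compound 4 is meta to a large group and in compound 2 is elsewhere on the ring, and in the group on the amine nitrogen of the shared core. With a single pair on each core, no rule for fluoro in this series can be drawn in either direction.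

The compounds shown leave open whether phenyl to 3-fluorophenyl would read the same on the core of compound 1, which would separate place from core. Also open, on these data alone, is whether a chloro, a methoxy or an amine at that same place would behave as the fluoro does in compound 4.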